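This account rests on a few compounds, and the source may have more. Where it says the series, first, only, none or still open, it means among the compounds named here.

- compound 1 `O=C(NCCCCc1ccccc1)n1cc(-c2ccccc2)oc1=O`: 0.667 h
- compound 2 `O=C(NCCCCc1ccccc1)n1cc(-c2ccc(F)cc2)oc1=O`: 1 h

Within the data shown here, these are the only two readings in an ADME assay on microsomes from liver (Mus musculus) for metabolic stability, read by LC-MS, using NADPH, tested at 4.6 uM (a lower number here means that the compound disappears faster, a higher number that the compound lasts longer), and they do not separate compound 1 from compound 2. Among the measured compounds shown here, the single measured step, a 1.5-fold higher number from compound 1 to compound 2 (0.18 log units; within the scatter), is fluoro in place of hydrogen on an aromatic carbon.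

Compound 3 `CN1CCC(c2cccc(-c3cn(C(=O)NCCCCc4ccccc4)c(=O)o3)c2)CC1` departs from compound 1 by a new change: 1-methylpiperidin-4-yl in place of hydrogen on an aromatic carbon. In words, it is 1-methylpiperidin-4-yl in place of hydrogen on an aromatic carbon. For the measured compounds named here, the fluoro step is the only guide, and it bears weakly. A much larger group enters here. That step, a 1.5-fold higher number from compound 1 to compound 2 (0.18 log units; within the scatter), gives no direction, so no shift beyond the scatter is expected in this assay, although the uncertainty is wide. The expected change is a 1.3-fold lower number from compound 1 to compound 3 (0.13 log units; within the scatter). For compound 3 the estimated half-life is 0.5 h, with an expected range of 0.15 h to 1.5 h.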

Compound 3, half-life: 0.5 h
Compound 3: middle estimate and measured number agree at the digits printed; measured number inside the range.
By their numbers in this assay, from the lowest: compounds 3, 1 and 2 (each within the scatter of the next).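

In this assay, the step of a 1.3-fold lower number from compound 1 to compound 3 (0.13 log units; within the scatter) shows that this position, meta to a large group on the six-membered aromatic ring of carbon only, accepts a group far larger than fluoro without a reading that separates the two compounds. The earlier compounds shown here showed only the replacement of hydrogen by a single fluoro atom, whereas this step brings in a six-membered non-aromatic ring with a hetero atom, and the half-lives still lie within the scatter of each other. Nothing measured here offers an explanation for this result.

Still open, going by these compounds, is whether piperidin-4-yl without the methyl on nitrogen, a carboxylic acid or a simple dimethylaminomethyl group would read the same at this position. Also open, on these data alone, is how 1-methylpiperidin-4-yl reads on the other carbons of this ring.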